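A few compounds are considered here, and "the series" means these few. Any claim that something is new, unique, unknown or untested is made for them only; others in the source may bear on it.

Measured so far:
compound 1 `N#CC1=C(N)Oc2c(N)cc3nc4ccccc4nc3c2C12C(=O)N(Cc1cnnn1-c1ccccc1Cl)c1ccccc12` — in a functional assay on HCT-116 cells (Homo sapiens) for antiproliferative activity, read by MTT assay, with a stated time of 48 h (a lower number here means a stronger inhibitor, a higher number a weaker inhibitor), compound 1 gives > 50000 nM, which is a limit of the assay.
compound 2 `Cc1cc(C)cc(-n2nncc2CN2C(=O)C3(C(C#N)=C(N)Oc4c(N)cc5nc6ccccc6nc5c43)c3ccccc32)c1` — in this assay compound 2 gives > 50000 nM, likewise a limit.

Among the compounds with values here, compound 2 stands on no number at all in this assay: its entry is a limit, and the one further value shown, that of compound 1, is a limit as well. Within the data shown here, the single measured step, a step that the two limits leave unreadable from compound 1 to compound 2, therefore cannot be sized; both of its ends sit at the limit of > 50000 nM in this assay, at which 2 of the 2 values shown sit.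

Compound 3 `CCc1cccc(CC)c1-n1nncc1CN1C(=O)C2(C(C#N)=C(N)Oc3c(N)cc4nc5ccccc5nc4c32)c2ccccc21` differs from compound 2 by 2,6-diethylphenyl in place of 3,5-dimethylphenyl on an aromatic nitrogen. Among the measured compounds shown here, only the step from compound 1 to compound 2 changes the group on the same aromatic nitrogen, and it is unreadable, so it gives no direction for this change. With both shown values at the limit of > 50000 nM in this assay, at which 2 of the 2 values shown sit, the expectation for compound 3 is that this assay again reports a limit rather than a number. The estimate for compound 3 is 70000 nM, with a range of 20000 nM to 200000 nM. The implied step, a step that the limit leaves unreadable from compound 2 to compound 3, is expected to stay within the scatter, though a limit would leave it unreadable.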

Compound 3, half-maximal inhibitory concentration: 37600 nM
Beside the measured number, compound 3's estimate is 1.9-fold (0.27 log units) above it; the measured number falls inside the stated range.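

In this assay, within the data shown here, compound 3, with 2,6-diethylphenyl on the aromatic nitrogen, is the only one of the three compounds to give a number rather than a limit, 37600 nM. This gives the position its first readable lower bounds: an at least 1.3-fold lower number from compound 2 to compound 3 (0.12 log units; that floor lies within the scatter), and an at least 1.3-fold lower number from compound 1 to compound 3 (0.12 log units; that floor lies within the scatter). Each is only a floor, so neither establishes a change beyond the scatter, and the step between the other two compounds still cannot be read, as both sit at a limit: the limit of > 50000 nM in this assay, at which 2 of the 3 values shown sit.

Going by these compounds, it remains open how far compound 1 and compound 2 truly lie from compound 3, and so whether swapping the group on this nitrogen matters at all in this assay. The compounds shown also do not separate the effect of the two ethyl groups from that of their placement on the phenyl ring, and a 2,6-dimethylphenyl, a 3,5-diethylphenyl or a ring carrying an amine or a carboxylic acid would be needed to test how far the number follows the group.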